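Thiophene for methylphenyl on the acylthiourea of compound 3

The source may report more compounds than this note shows. Statements on the series, on what has been measured and on what is new or still open speak of the compounds shown alone.

Compound 1: `O=C(NC(=S)N1CCc2ccc(OCc3ccccc3)cc21)c1ccccc1` with 43800 nM
Compound 2: `O=C(NC(=S)N1CCc2c(OCCCCCOc3ccc(Cl)cc3)cccc21)c1cccc([N+](=O)[O-])c1` with 12100 nM
Compound 3: `Cc1ccc(C(=O)NC(=S)N2CCc3c(OCCCCCOc4ccc(Cl)cc4)cccc32)cc1` with > 50000 nM

The study measured three compounds in an ADME assay on Huh-7 cells (Homo sapiens) for cytotoxicity; a lower number here means that less compound is tolerated, a higher number that more compound is tolerated. Compound 1 `O=C(NC(=S)N1CCc2ccc(OCc3ccccc3)cc21)c1ccccc1` gives 43800 nM and compound 2 `O=C(NC(=S)N1CCc2c(OCCCCCOc3ccc(Cl)cc3)cccc21)c1cccc([N+](=O)[O-])c1` gives 12100 nM. Compound 3 `Cc1ccc(C(=O)NC(=S)N2CCc3c(OCCCCCOc4ccc(Cl)cc4)cccc32)cc1` reaches only a limit of the assay, > 50000 nM, so for compound 3 a range rather than a number is known, at the upper edge of the values shown. Among the measured compounds shown here, the one measured step, an at least 4.1-fold higher number from compound 2 to compound 3 (0.61 log units; beyond the scatter), ends at that edge, because the limit of > 50000 nM in this assay, at which 1 of the 3 values shown sits, marks the point beyond which the assay reports nothing more.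

Compound 4 `O=C(NC(=S)N1CCc2c(OCCCCCOc3ccc(Cl)cc3)cccc21)c1cccs1` carries the change (thiophen-2-yl in place of 4-methylphenyl on a carbonyl carbon). For the measured compounds named here, no measured step exchanges a carbocyclic aryl for thiophen-2-yl on a carbonyl carbon, so the step from compound 2 to compound 3 bears on it only in showing where compound 3 stands. She expects for compound 4 a step of an at least 1.1-fold lower number from compound 3 to compound 4 (0.04 log units; that floor lies within the scatter), that is, a number within the scatter or again a limit. Compound 4 is estimated at 45000 nM, in the range 20000 nM to 100000 nM.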

Compound 4, half-maximal cytotoxic concentration: 10700 nM
For compound 4 the middle estimate is 4.2-fold (0.62 log units) above the measured one; measured number outside the range, below it.
By their numbers in this assay, from the lowest: compounds 4 and 2 (each within the scatter of the next); then compound 1. At a limit, above all of these: compound 3.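

Thiophen-2-yl in place of 4-methylphenyl on a carbonyl carbon gives an at least 4.6-fold lower number from compound 3 to compound 4 (0.66 log units; beyond the scatter) in this assay, so a five-membered aromatic ring with a sulfur atom does not keep the number reached with 4-methylphenyl. Set against 3-nitrophenyl, thiophen-2-yl gives a 1.1-fold lower number from compound 2 to compound 4 (0.05 log units; within the scatter), so these two different groups cannot be told apart here, and among the three groups at this place 4-methylphenyl alone stands out. Compound 3 stands at a limit of the assay, so the size of the step to compound 4 is only a floor: the limit of > 50000 nM in this assay, at which 1 of the 4 values shown sits.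

As far as these compounds go, whether the methyl group or the six-membered carbon ring sets 4-methylphenyl apart stays open. A plain phenyl or a methyl-bearing thiophene at this place on the shared core would bear on that question.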